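A few compounds are considered here, and "the series" means these few. Any claim that something is new, unique, unknown or untested is made for them only; others in the source may bear on it.

Measured in a toxicity assay on MT2 cells (Homo sapiens) for cytotoxicity, read by XTT assay, with a stated time of 4 days; on this read-out higher numbers stand for lower toxicity in this test and lower numbers for higher toxicity in this test:
Compound 1 `Cc1nc(C)c([C@H](OC(C)(C)C)C(=O)O)c(N2CCC(C)(C)CC2)c1-c1ccc(OCCc2ccc(F)cc2F)cc1` gives >= 33500 nM
Compound 2 `Cc1nc(C)c([C@H](OC(C)(C)C)C(=O)O)c(N2CCC(C)(C)CC2)c1-c1ccc(OCCc2cc(F)ccc2F)cc1` gives >= 33500 nM
Compound 3 `Cc1nc(C)c([C@H](OC(C)(C)C)C(=O)O)c(N2CCC(C)(C)CC2)c1-c1ccc(OCCCc2ccc(F)cc2)cc1` gives >= 32000 nM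

Compound 2 has no exact number here, since >= 33500 nM is a limit of this assay and not a measured value. The whole series sits on limits: the limit of >= 33500 nM in this assay, at which 2 of the 3 values shown sit, and the limit of >= 32000 nM in this assay, at which 1 of the 3 values shown sits, are all that is known so far.

Compound 4 `Cc1nc(C)c([C@H](OC(C)(C)C)C(=O)O)c(N2CCC(C)(C)CC2)c1-c1ccc(OCCc2ccccn2)cc1` differs from compound 2 in one place, with pyridin-2-yl in place of 2,5-difluorophenyl on a saturated chain carbon, two bonds along the chain from an oxygen on an aromatic ring.

Three measured steps change the group at this same place: a step that the two limits leave unreadable from compound 1 to compound 2, a step that the two limits leave unreadable from compound 1 to compound 3 and a step that the two limits leave unreadable from compound 2 to compound 3. None of the three has a size that can be read, and none brings in a ring with a hetero atom.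

The expectation therefore rests on compound 2 and its limit of >= 33500 nM, with no step beyond the usual scatter expected in this assay in either direction. The expected change is a step that the limit leaves unreadable from compound 2 to compound 4, and a further limit is the likeliest report. For compound 4 the estimated value is 36000 nM, with an expected range from 20000 nM to 50000 nM.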

Compound 4, half-maximal cytotoxic concentration: >= 25000 nM
Compound 4 gave a limit, no number; the forecaster's own chance of this, stated with the estimate: 80%; the middle value does not contradict the limit.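

In this assay compound 4 gives >= 25000 nM, which is a limit and not a number. The steps to compound 4 from compound 1, compound 2 and compound 3 all join two limits and cannot be read. The compounds shown leave open whether changing the group at this place alters the toxicity in this assay at all.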